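Replacing naphthalen-2-yl with 4-fluorophenyl on the oxygen

The compounds below may be only part of what the source reports. "The series", "measured", "known", "first", "only" and "open" are said of these compounds alone.

Measured in a functional assay on DU-145 cells (Homo sapiens) for inhibition, read by MTT assay, with a stated time of 72 h; a higher number here means a weaker inhibitor, a lower number a stronger inhibitor:
Compound 1 `O=C(O)CCCCCCC(=O)Nc1ccc(C2=C(c3ccc(O)cc3)C3CC(S(=O)(=O)Oc4ccccc4C(F)(F)F)C2O3)cc1` > 100000 nM
Compound 2 `O=C(O)CCCCCCC(=O)Nc1ccc(C2=C(c3ccc(O)cc3)C3CC(S(=O)(=O)Oc4ccc5ccccc5c4)C2O3)cc1` 58300 nM

Compound 1 shows > 100000 nM, which is a limit of the assay, not a number. Among the compounds with values here, compound 2 carries the only actual number so far, 58300 nM.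

The next structure, compound 3 `O=C(O)CCCCCCC(=O)Nc1ccc(C2=C(c3ccc(O)cc3)C3CC(S(=O)(=O)Oc4ccc(F)cc4)C2O3)cc1`, differs from compound 2 in one place: 4-fluorophenyl in place of naphthalen-2-yl on an oxygen. This puts 4-fluorophenyl in place of naphthalen-2-yl on an oxygen whose other neighbour is the sulfonyl sulfur.

Within the data shown here, one measured step bears on this change, made at the same oxygen: an at least 1.7-fold lower number from compound 1 to compound 2 (0.23 log units; that floor lies within the scatter). Among the measured compounds shown here, it is the only guide, and its true size is unknown. Compound 1, also a substituted phenyl on that oxygen, stands at the limit of > 100000 nM in this assay, at which 1 of the 2 values shown sits. On that basis, a small move towards a higher number is expected in this assay, and the assay may return only a limit. The estimated step is a 1.4-fold higher number from compound 2 to compound 3 (0.14 log units; within the scatter). For compound 3 the estimated value is 80000 nM, with an expected range of 38000 nM to 160000 nM.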

Compound 3, half-maximal inhibitory concentration: > 100000 nM
Compound 3 gave a limit, no number (the forecaster's own chance of this, stated with the estimate: 45%); middle value at least 1.2-fold (0.09 log units) away from the limit.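

At the oxygen whose other neighbour is the sulfonyl sulfur, the change from naphthalen-2-yl to 4-fluorophenyl in this assay gives an at least 1.7-fold higher number from compound 2 to compound 3 (0.23 log units; that floor lies within the scatter), so the readable part of this step does not by itself separate the two compounds. Within the data shown here, compound 3 now joins compound 1 at the assay limit, which leaves compound 2, with naphthalen-2-yl, as the only compound of the three with an actual number, while both substituted phenyl groups on this oxygen, 2-(trifluoromethyl)phenyl and 4-fluorophenyl, end at the limit: the limit of > 100000 nM in this assay, at which 2 of the 3 values shown sit. Both compound 1 and compound 3 carry limits, so the step between them cannot be read and the two phenyl groups cannot be ranked against each other.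

Going by these compounds, how far compound 1 and compound 3 lie past the limit remains open, as does whether the number for compound 2 goes with its second aromatic ring or with some other feature of naphthalen-2-yl. An unsubstituted phenyl, a pyridyl group or a methoxy-bearing naphthalene on the same oxygen could help to separate these readings.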